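This account rests on a few compounds, and the source may have more. Where it says the series, first, only, none or still open, it means among the compounds named here.

Compound 1 `CC(C)CN(CC(C)C)c1ccc(/C(=N/O)Nc2ccc(F)c(Br)c2)cc1NC(=O)NC1CCCCC1` was tested in an assay on isolated protein for inhibition of Indoleamine 2,3-dioxygenase 1 (Homo sapiens) (on this read-out lower numbers stand for stronger inhibition and higher numbers for weaker inhibition), where compound 1 reached only the limit > 3000 nM. For the measured compounds named here, compound 2 `Cc1ccc(NC(=O)Nc2cc(/C(=N/O)Nc3ccc(F)c(Br)c3)ccc2N(CC(C)C)CC(C)C)cc1` gave 2300 nM in this assay, the single number among the two results. The other result is a limit (the limit of > 3000 nM in this assay, at which 1 of the 2 values shown sits). The step of an at least 1.3-fold lower number from compound 1 to compound 2 (0.11 log units; that floor lies within the scatter) alters the urea end of the shared core. Going by the values given here, compound 3 `Cc1ccc(NC(=O)Nc2cc(/C(=N/O)Nc3ccc(C)cc3)ccc2N(CC(C)C)CC(C)C)cc1` differs from compound 2 by 4-methylphenyl in place of 3-bromo-4-fluorophenyl on an amine nitrogen, a change at a different place, so the one measured step does not bear on it and no direction beyond the scatter is indicated. Compound 3 is therefore expected near 3500 nM, between 1200 nM and 10000 nM, an expected step of a 1.5-fold higher number from compound 2 to compound 3 (0.18 log units; within the scatter).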

Compound 3, half-maximal inhibitory concentration: 1560 nM
The estimate for compound 3 lay 2.2-fold (0.35 log units) above the measured number; low and high end bracket the measured number.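

On the amine nitrogen, 4-methylphenyl in place of 3-bromo-4-fluorophenyl gives a 1.5-fold lower number from compound 2 to compound 3 (0.17 log units; within the scatter) in this assay. This end of the shared core, which the earlier step did not touch, therefore accepts the loss of both bromine and fluorine with no change beyond the scatter. Nothing measured here gives a reason for this step. Still open, from the compounds shown here alone, is whether a pyridyl ring or a carboxylic acid on the phenyl ring at this amine nitrogen would shift the number beyond the scatter.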